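Replacing the Ring-Nitrogen Benzyl Group of Compound 3

The compounds below may be only part of what the source reports. "The series", "measured", "known", "first", "only" and "open" are said of these compounds alone.

Compound 1 `NC(=O)c1c(NC(=O)c2ccc(C(F)(F)F)cc2)sc2c1CCN(Cc1c(Cl)cccc1Cl)C2` gives 8530 nM in a functional assay on MKN-74 cells (Homo sapiens) for antiproliferative activity, with a stated time of 24 h; a higher number here means a weaker inhibitor, a lower number a stronger inhibitor. Compound 2 `Cc1ccc(C(=O)Nc2sc3c(c2C(N)=O)CCN(Cc2c(Cl)cccc2Cl)C3)cc1` gives 12300 nM. Compound 3 `NC(=O)c1c(NC(=O)c2cccc([N+](=O)[O-])c2)sc2c1CCN(Cc1c(Cl)cccc1Cl)C2` gives 13500 nM.

Compound 3 sits alongside the other two on these numbers: the step of a 1.6-fold higher number from compound 1 to compound 3 (0.20 log units; within the scatter) and the step of a 1.1-fold higher number from compound 2 to compound 3 (0.04 log units; within the scatter) are both within the scatter, as is a 1.4-fold higher number from compound 1 to compound 2 (0.16 log units; within the scatter). Compound 4 `NC(=O)c1c(NC(=O)c2cccc([N+](=O)[O-])c2)sc2c1CCN(C(=O)Nc1ccccc1Cl)C2` differs from compound 3 in one place: (2-chlorophenyl)carbamoyl in place of 2,6-dichlorobenzyl on an amine nitrogen in a ring. None of the three measured steps touches this position; each of them changes only the aryl group on the carbonyl carbon, and each fell within the scatter. Going by the values given here, no measured step therefore bears on the change from compound 3 to compound 4, and the expectation rests on compound 3 alone, with a wide range. Compound 4 is expected to give 13500 nM, between 3000 nM and 60000 nM. The expected step is no change at the digits printed from compound 3 to compound 4 (within the scatter), not beyond the scatter.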

Compound 4, half-maximal inhibitory concentration: 22700 nM
Estimate against measurement, compound 4: 1.7-fold (0.23 log units) below, and the stated range covers the measured number.
By their numbers in this assay, from the lowest: compounds 1, 2, 3 and 4 (each within the scatter of the next, the first and the last beyond it).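

Going by these compounds alone, the earlier steps changed only the aryl group on the carbonyl carbon, so this is the first reading at the amine nitrogen in the ring. In this assay, (2-chlorophenyl)carbamoyl in place of 2,6-dichlorobenzyl gives a 1.7-fold higher number from compound 3 to compound 4 (0.23 log units; within the scatter), so swapping the benzyl link for a carbamoyl link, with its hydrogen-bond donor and acceptor, leaves the number within the scatter. Nothing available explains this result.

Going by these compounds, whether a simple methyl, an acetyl or a methanesulfonyl group on this nitrogen would also stay within the scatter remains open. So does whether the same exchange would read alike with the aryl amides of compound 1 and compound 2.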